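The source may hold more compounds than are shown below. What is called first, only, known or untested is meant among the compounds shown, and "the series" means these compounds.

Measured so far:
- Compound 1 `COc1ccc(N/C=C\C(=O)c2nc(-c3ccc(C(F)(F)F)cc3)n3ccccc23)cc1OC`; in a functional assay on BT-474 cells (Homo sapiens) for cytotoxicity, read by MTT assay, with a stated time of 48 h (on this read-out lower numbers stand for stronger inhibition and higher numbers for weaker inhibition), compound 1 gives > 30000 nM, which is a limit of the assay and not a number.
- Compound 2 `O=C(/C=C\Nc1cnc2ccccc2c1)c1nc(-c2ccccc2)n2ccccc12`; in this assay compound 2 gives 19700 nM.
- Compound 3 `COc1ccc(N/C=C\C(=O)c2nc(-c3ccc(F)cc3)n3ccccc23)cc1`; in this assay compound 3 gives 15700 nM.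

Compound 1 stands at the edge of what this assay reports: the limit of > 30000 nM in this assay, at which 1 of the 3 values shown sits. Compounds 2 and 3 give numbers, and those two numbers lie close to each other. For the measured compounds named here, no two of the measured compounds differ in only one place, so no step between them can be counted, and the values of compounds 2 and 3 show only that weak inhibition is reachable within this shared core.

Compound 4 `O=C(/C=C\Nc1ccc(Cl)cc1)c1nc(-c2ccc(C(F)(F)F)cc2)n2ccccc12` has not yet been measured. It differs from compound 1 by 4-chlorophenyl in place of 3,4-dimethoxyphenyl on an amine nitrogen, while the trifluoromethyl-bearing ring of compound 1 is kept. Since compound 1 offers only a limit, the size of this step cannot be anchored; the step of an at least 1.5-fold lower number from compound 1 to compound 4 (0.17 log units; that floor lies within the scatter) is expected to be modest, towards somewhat stronger inhibition, but a limit for compound 4 as well would be no surprise. Compound 4 is therefore estimated at 20000 nM, with a range from 6000 nM to 60000 nM.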

Compound 4, half-maximal inhibitory concentration: 3820 nM
Compound 4: the middle estimate sits 5.2-fold (0.72 log units) above what was measured, and the stated range ends above it.
By their numbers in this assay, from the lowest: compound 4; then compounds 3 and 2 (each within the scatter of the next). At a limit, above all of these: compound 1.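

For the compounds shown here, replacing the aryl group on the amine nitrogen gives the first change in this set whose size can be read: in this assay, the trifluoromethyl-bearing ring is kept and the step is an at least 7.8-fold lower number from compound 1 to compound 4 (0.89 log units; beyond the scatter). The group at this position therefore affects the read-out, and 3,4-dimethoxyphenyl and 4-chlorophenyl are not interchangeable there, which compound 2 and compound 3 could not show, as neither differs in only one place from another compound shown. The step is only a floor on the true difference, because one end of it is a limit: the limit of > 30000 nM in this assay, at which 1 of the 4 values shown sits.

The compounds shown do not separate the effect of 4-chlorophenyl entering from that of 3,4-dimethoxyphenyl leaving. On these data alone, how a plain phenyl or a bromophenyl on this nitrogen would read also stays open.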